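The compounds below may be only part of what the source reports. "The series", "measured", "known", "first", "only" and "open" are said of these compounds alone.

Compound 1 `CC(C)(C)NC(=O)Nc1ncccc1OCc1ccccc1`: > 10000 nM
Compound 2 `CC(C)(C)CC(C)(C)NC(=O)Nc1ncccc1OCc1cccc(F)c1`: > 10000 nM

In an ADME assay on N2a cells (Mus musculus) for cytotoxicity, read by MTT assay, with a stated time of 72 h (on this read-out lower numbers stand for stronger inhibition and higher numbers for weaker inhibition), compound 1 gives > 10000 nM as a limit of the assay, not a number. Compound 2 gives > 10000 nM, which is likewise a limit. Among the compounds with values here, both measured compounds therefore stand at one value, (the limit of > 10000 nM in this assay, at which 2 of the 2 values shown sit), and no step between measured compounds is available as a guide.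

Compound 3 `CC(C)(C)NC(=O)Nc1ncccc1OCc1ccc(Cl)cc1` has not yet been measured. It is compound 1 with chloro in place of hydrogen on an aromatic carbon, para to a large group (chloro in place of hydrogen on an aromatic carbon), or phenyl to 4-chlorophenyl when the difference is cut one bond further out.

No change beyond the usual scatter is expected in this assay, and the expected a number no higher from compound 1 to compound 3 (the limit leaves the size open) is small. Compound 3 is estimated at 10000 nM, with an expected range from 4000 nM to 20000 nM, and it may well be reported only as a limit.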

Compound 3, half-maximal inhibitory concentration: > 10000 nM
Compound 3 gave a limit, no number (the forecaster's own chance of this, stated with the estimate: 80%); the middle value sits exactly at the limit.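

In this assay compound 3 gives > 10000 nM, which is a limit and not a number. Within the data shown here, compound 1 also stands at a limit, so no step between compound 1 and compound 3 can be read: the limit of > 10000 nM in this assay, at which 3 of the 3 values shown sit. The compounds shown leave open whether chloro in place of hydrogen changes the value at all, since none of them gives a number in this assay.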